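The compounds below may be only part of what the source reports. "The series", "measured", "known", "first", "only" and "open" are said of these compounds alone.

Measured so far in an ADME assay on HEK293 cells (Homo sapiens) for cytotoxicity, with a stated time of 72 h; a higher number here means that more compound is needed for the effect, a lower number that less compound is needed:
- compound 1, `Cc1cc(NC(=O)Nc2ncccc2C)c2ccccc2n1`: > 25000 nM (a limit of this assay, not a number)
- compound 2, `Cc1cc(NC(=O)Nc2ccccc2C(F)(F)F)c2ccccc2n1`: > 25000 nM (a limit of this assay, not a number)
- compound 3, `Cc1cc(NC(=O)Nc2ccc(N)cc2)c2ccccc2n1`: > 25000 nM (a limit of this assay, not a number)

Compound 3 thus stands at the limit of > 25000 nM in this assay, at which 3 of the 3 values shown sit, and no finite half-maximal effective concentration is available for it. Within the data shown here, the only measured change at the same position, a step that the two limits leave unreadable from compound 1 to compound 3, is unreadable: both ends sit at the limit. Compound 2, which also carries a substituted phenyl on the amide-type nitrogen, sits at the limit as well.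

Compound 4, `Cc1cc(NC(=O)Nc2ccccc2F)c2ccccc2n1`, differs from compound 3 by 2-fluorophenyl in place of 4-aminophenyl on an amide-type nitrogen. Among the measured compounds shown here, no measured step in this assay bears readably on this change; what is shared is that every measured member of the series stays at the limit. The step of a number no higher from compound 3 to compound 4 (the limit leaves the size open) is therefore expected to be none beyond the scatter, with the result most likely reported again as a limit. Compound 4 is estimated at 25000 nM, with a range from 12000 nM to 60000 nM.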

Compound 4, half-maximal effective concentration: > 25000 nM
Compound 4: only a limit was reported (the forecaster's own chance of this, stated with the estimate: 85%); the middle value sits exactly at the limit.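

In this assay compound 4 gives > 25000 nM as a limit of the assay, not a number. No step from compound 1, compound 2 or compound 3 to compound 4 can be read: the limit of > 25000 nM in this assay, at which 4 of the 4 values shown sit.

The compounds shown leave open which change on the amide-type nitrogen, if any, would give a finite half-maximal effective concentration.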